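The source may hold more compounds than are shown below. What is called first, only, known or untested is meant among the compounds shown, and "the series" means these compounds.

Of the compounds shown here, two of the same core have been measured for growth inhibition. Compound 1 `O=C(Nc1ccc(Cc2ccccc2)cc1)Nc1nn(C(=O)Nc2ccc(Cc3ccccc3)cc2)c2ccccc12` is the larger of the pair, carrying a second urea arm on the amino group; in a functional assay on SF-268 cells (Homo sapiens) for inhibition, read by sulforhodamine B assay, with a stated time of 48 h (on this read-out lower numbers stand for stronger inhibition of growth and higher numbers for weaker inhibition of growth), compound 1 gives 75600 nM. Compound 2 `Nc1nn(C(=O)Nc2ccc(Cc3ccccc3)cc2)c2ccccc12` keeps the free amino group and only the carbamoyl substituent on the ring nitrogen, and in this assay compound 2 gives 4660 nM. On the numbers at hand, compound 2 stands lowest: compound 1 gives the higher number, and that gap lies beyond the usual scatter.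

Compound 3 `CCCCOc1ccc(NC(=O)n2nc(N)c3ccccc32)cc1` is the next compound to be tested. It differs from compound 2 in one place: butoxy in place of benzyl on an aromatic carbon. Among the measured compounds shown here, no measured pair in this set shows what such an exchange does, so the expectation rests on compound 2 alone. The step from compound 2 to compound 3 is expected to be small, close to none beyond the scatter, with a slight leaning toward a weaker number a 1.4-fold higher number from compound 2 to compound 3 (0.14 log units; within the scatter). For compound 3 in this assay the estimate is 6500 nM, within a range from 2000 nM to 22000 nM.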

Compound 3, concentration for 50% growth inhibition: 25800 nM
For compound 3 the middle estimate is 4.0-fold (0.60 log units) below the measured one; measured number above the stated range.
By their numbers in this assay, from the lowest: compound 2; then compound 3; then compound 1.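

In this assay, putting butoxy in place of benzyl on an aromatic carbon, para to a large group, gives a 5.5-fold higher number from compound 2 to compound 3 (0.74 log units; beyond the scatter), so what this position carries matters to the read-out. Among the compounds shown here, compound 1 and compound 2 both hold benzyl here and differ only elsewhere, so this step is the first reading of the position, and it shows that the ringless butoxy, with its oxygen and hydrogen-bond acceptor, does not match benzyl on this core. The exchange removes a ring, shortens the group and brings in oxygen all at once, and no measurement at hand accounts for the size of the step.

The compounds shown leave open which part of the exchange counts: a pentyl chain would keep carbon only without a ring, while a phenoxy group would keep the ring and bring in the oxygen. They also leave open how an amine or a carboxylic acid would read at this position, and whether the same step would appear on the core of compound 1 with its second urea arm.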